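The source may hold more compounds than are shown below. What is called first, only, known or untested is meant among the compounds shown, and "the series" means these compounds.

Three related compounds have been tested in a functional assay on THP-1 cells (Homo sapiens) for inhibition, read by sulforhodamine B assay, with a stated time of 48 h, tested at 50 uM; on this read-out lower numbers stand for less inhibition of growth and higher numbers for more inhibition of growth at the one concentration tested. Compound 1 `COc1cc(/C=C/C(=O)/C=C/c2ccco2)ccc1OCc1cn(CCCOc2cc(=O)oc3ccccc23)nn1` gives 57%, compound 2 `COc1cccc(/C=C/C(=O)/C=C/c2ccc(OCc3cn(CCOc4cc(=O)oc5ccccc45)nn3)c(OC)c2)c1` gives 77%, and compound 3 `COc1ccc(/C=C/C(=O)/C=C/c2ccc(OCc3cn(CCCCCOc4cc(=O)oc5ccccc45)nn3)c(OC)c2)cc1` gives 39%. Compound 1 therefore stands in the middle of the three, clearly under compound 2 and clearly over compound 3.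

The next compound to test is compound 4 `COc1cccc(/C=C/C(=O)/C=C/c2ccc(OCc3cn(CCCOc4cc(=O)oc5ccccc45)nn3)c(OC)c2)c1`, which keeps the rest of compound 1 and alters one end: 3-methoxyphenyl in place of furan-2-yl on a double-bonded chain carbon bound to a double-bonded chain carbon. Here 3-methoxyphenyl takes the place of furan-2-yl on a double-bonded chain carbon bound to a double-bonded chain carbon.

Within the data shown here, no tested pair shows this swap on its own, so the evidence is indirect. Among the measured compounds shown here, the only guide is compound 2, which also carries a 3-methoxyphenyl group and gives 77%, the highest number so far. A small upward step is expected, and the estimated change is a number 8 percentage points higher from compound 1 to compound 4 (within the scatter). For compound 4 the expected value is 65%, with an estimated range from 45% to 82%.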

Compound 4, percent growth inhibition at one concentration: 58%
For compound 4 the middle estimate is 7 percentage points above the measured one; low and high end bracket the measured number.
By their numbers in this assay, from the lowest: compound 3; then compounds 1 and 4 (each within the scatter of the next); then compound 2.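

In this assay, among these compounds, the swap of furan-2-yl for 3-methoxyphenyl on a double-bonded chain carbon bound to a double-bonded chain carbon gives a number 1 percentage points higher from compound 1 to compound 4 (within the scatter) and is the first direct reading of a change at this end of the molecule. At this place, then, a five-membered aromatic ring with 1 hetero atom and a six-membered aromatic ring of carbon only cannot be told apart on this read-out, even though the entering group has 8 heavy atoms against 5. No other measurement bears on why the two groups read alike.

From the compounds shown here alone, this is a single pair, so it remains open whether the same holds when the chain to the triazole nitrogen differs. A phenyl ring carrying an amine or a carboxylic acid at this place also remains an open case, as does a thiophen-2-yl group.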